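Amino in place of nitro: working notes

This account rests on a few compounds, and the source may have more. Where it says the series, first, only, none or still open, it means among the compounds named here.

- compound 1 `C=C[C@@](C)(/C=C/c1ccc(OC(=O)CCCC)cc1)CCC=C(C)C` gives 15%
- compound 2 `C=C[C@@](C)(/C=C/c1ccc(O)c([N+](=O)[O-])c1)CCC=C(C)C` gives 55%

Both values come from a functional assay on THP-1 cells (Homo sapiens) for inhibition, with a stated time of 48 h, tested at 50 uM; a higher number here means more inhibition of growth at the concentration tested, a lower number less inhibition of growth. Compound 2 stands highest of the two, and its gap to compound 1 lies beyond the scatter. These two compounds differ in more than one place, so that gap does not isolate any single structural change.

The next compound to be read is compound 3 `C=C[C@@](C)(/C=C/c1ccc(O)c(N)c1)CCC=C(C)C`. It keeps the core of compound 2 but carries amino in place of nitro on an aromatic carbon, ortho to a hydroxy group and meta to a large group: amino in place of nitro on an aromatic carbon. Within the data shown here, no measured pair shows this exchange, so the expectation is loose and its range is wide. The anchor is compound 2 at 55%, and a moderate loss of growth inhibition in this assay is expected from that level, though a result within the scatter would not surprise. The expected change is a number 13 percentage points lower from compound 2 to compound 3 (beyond the scatter). The estimated value for compound 3 is 42%, with an expected range from 20% to 68%.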

Compound 3, percent growth inhibition at one concentration: 48%
For compound 3 the middle estimate is 6 percentage points below the measured one; the range from low to high includes it.
By their numbers in this assay, from the lowest: compound 1; then compounds 3 and 2 (each within the scatter of the next).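

In this assay, the exchange of nitro (3 heavy atoms) for amino (1 heavy atom) on an aromatic carbon, ortho to a hydroxy group and meta to a large group, gives a step of a number 7 percentage points lower from compound 2 to compound 3 (within the scatter). Among these compounds, this is the first comparison that isolates one structural change, and at this position the read-out does not separate the two groups: in this pair, growth inhibition at the tested concentration does not depend on nitro being present. No measurement on hand bears on why the two groups read alike.

Still open, as far as these compounds go, is whether other groups on this aromatic carbon, such as a methoxy group, an acetamide or a carboxylic acid, would read apart from nitro and amino. Also open, from the compounds shown here alone, is what the hydroxy group itself contributes, as compound 1 differs from both compound 2 and compound 3 in more than one place and so offers no single-change comparison.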